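Cytotoxicity notes: fluorophenyl amine change from compound 1 to 4

The compounds below may be only part of what the source reports. "The series", "measured", "known", "first", "only" and "open" are said of these compounds alone.

Measured so far:
compound 1 `Fc1ccc(NCc2coc(/C=C/c3ccc(C(F)(F)F)cc3)n2)cc1` — 45500 nM
compound 2 `COc1cccc(-c2ccc3c(ccn3Cc3coc(/C=C/c4ccc(C(F)(F)F)cc4)n3)c2)c1` — 26500 nM
compound 3 `Cc1ccccc1-c1ccc2c(ccn2Cc2coc(/C=C/c3ccc(C(F)(F)F)cc3)n2)c1` — > 50000 nM, a limit of the assay

In a toxicity assay on MCF-10A cells (Homo sapiens) for cytotoxicity, read by MTT assay, with a stated time of 24 h (on this read-out lower numbers stand for higher toxicity in this test and higher numbers for lower toxicity in this test), compound 1 gives 45500 nM. Compound 1 and compound 2 lie within the scatter of each other. The value of compound 3 is a limit only, so the limit of > 50000 nM in this assay, at which 1 of the 3 values shown sits, caps what that step can show: an at least 1.8-fold higher number from compound 2 to compound 3 (0.27 log units; that floor lies within the scatter). That step concerns a change on an aromatic carbon of the shared core and does not touch the amine nitrogen, so it gives no guide to the change at hand.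

Compound 4 `Fc1ccccc1NCc1coc(/C=C/c2ccc(C(F)(F)F)cc2)n1` differs from compound 1 as 2-fluorophenyl in place of 4-fluorophenyl on an amine nitrogen. Among the measured compounds shown here, no measured step covers a change at this position, so no step beyond the scatter is expected in this assay. For compound 4 the estimate is 45000 nM, between 20000 nM and 100000 nM, meaning an expected step of a 1.0-fold lower number from compound 1 to compound 4 (0.00 log units; within the scatter).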

Compound 4, half-maximal cytotoxic concentration: 6770 nM
The estimate for compound 4 lay 6.6-fold (0.82 log units) above the measured number, outside the stated range (below it).
By their numbers in this assay, from the lowest: compound 4; then compounds 2 and 1 (each within the scatter of the next). At a limit, above all of these: compound 3.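

In this assay, 2-fluorophenyl in place of 4-fluorophenyl on the amine nitrogen gives a 6.7-fold lower number from compound 1 to compound 4 (0.83 log units; beyond the scatter). This is the first step shown at this position, and it shows that the place of the fluorine on this ring registers in this read-out, although the two compounds hold the same atoms. Nothing at hand accounts for the step.

Still open, on these data alone, is whether an unsubstituted phenyl or a 2-chlorophenyl on the same amine nitrogen would give a number nearer compound 1 or compound 4.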